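Anilino variation on a shared nitrile core

The compounds below may be only part of what the source reports. "The series", "measured", "known", "first", "only" and "open" are said of these compounds alone.

Measured compounds:
compound 1 `N#Cc1c(Nc2ccc(Cl)cc2)nc(SCc2cn(Cc3ccccc3Cl)nn2)nc1-c1ccccc1` gives 6520 nM in a functional assay on MCF7 cells (Homo sapiens) for inhibition, read by MTT assay, with a stated time of 72 h; a lower number here means a stronger inhibitor, a higher number a weaker inhibitor
compound 2 `COc1ccccc1Nc1nc(SCc2cn(Cc3ccccc3Cl)nn2)nc(-c2ccccc2)c1C#N` gives 6170 nM in this assay

Compound 2 has the lowest of the two numbers, but its step from compound 1 is a 1.1-fold lower number from compound 1 to compound 2 (0.02 log units; within the scatter), so the two compounds cannot be told apart. Compound 3 `N#Cc1c(Nc2ccccc2)nc(SCc2cn(Cc3ccccc3Cl)nn2)nc1-c1ccccc1` is not yet measured. Its change from compound 2 is hydrogen in place of methoxy on an aromatic carbon. Going by the values given here, the only measured step, a 1.1-fold lower number from compound 1 to compound 2 (0.02 log units; within the scatter), shows that replacing one substituted aryl group on that nitrogen by another left the number unchanged, so no step beyond the scatter is expected here either, in either direction. For compound 3 the expected step is a 1.1-fold higher number from compound 2 to compound 3 (0.02 log units; within the scatter), giving an estimate of 6500 nM with a range of 3000 nM to 14000 nM in this assay.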

Compound 3, half-maximal inhibitory concentration: > 64000 nM
Compound 3 ended at the assay's limit; the forecaster's own chance of this, stated with the estimate: 5%; at least 9.8-fold (0.99 log units) between middle value and limit.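

In this assay, the bare phenyl behaves differently from both substituted aryl groups: hydrogen in place of methoxy gives an at least 10-fold higher number from compound 2 to compound 3 (1.01 log units; beyond the scatter), and hydrogen in place of chloro gives an at least 9.8-fold higher number from compound 1 to compound 3 (0.99 log units; beyond the scatter). A substituent on this ring therefore matters even though exchanging 4-chlorophenyl for 2-methoxyphenyl left the number within the scatter. The value of compound 3 is a limit of the assay: the limit of > 64000 nM in this assay, at which 1 of the 3 values shown sits.

Open, from the compounds shown here alone, is whether other groups on this ring, such as a hydroxyl, an amine or an ethoxy chain, would give numbers like those of compound 1 and compound 2. Also open, going by these compounds, is how much of the result depends on where on the ring the substituent sits.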